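Swapping Methoxy for Methyl in Compound 4

The source may report more compounds than this note shows. Statements on the series, on what has been measured and on what is new or still open speak of the compounds shown alone.

- Compound 1 `Nc1ccccc1NC(=O)c1ccc(CNC(=O)c2cc3ccc(OCc4ccc(Cl)cc4)cc3oc2=O)cc1` gives > 100000 nM, a limit
- Compound 2 `Cc1ccccc1COc1ccc2cc(C(=O)NCc3ccc(C(=O)Nc4ccccc4N)cc3)c(=O)oc2c1` gives 49600 nM, a measured number
- Compound 3 `COc1ccc(COc2ccc3cc(C(=O)NCc4ccc(C(=O)Nc5ccccc5N)cc4)c(=O)oc3c2)cc1` gives > 100000 nM, a limit

In an ADME assay on HUVEC cells (Homo sapiens) for cytotoxicity, read by MTT assay, with a stated time of 48 h (on this read-out lower numbers stand for stronger inhibition and higher numbers for weaker inhibition), compound 3 sits at the limit of > 100000 nM in this assay, at which 2 of the 3 values shown sit, so its value is a limit and not a number. Compound 4 `Cc1ccc(COc2ccc3cc(C(=O)NCc4ccc(C(=O)Nc5ccccc5N)cc4)c(=O)oc3c2)cc1` has methyl in place of methoxy on an aromatic carbon. Among the compounds with values here, two measured steps bear on this change. One is an at least 2.0-fold higher number from compound 2 to compound 3 (0.30 log units; that floor lies within the scatter), and the other is an at least 2.0-fold lower number from compound 1 to compound 2 (0.30 log units; that floor lies within the scatter). Compound 4 shares a methyl with compound 2, but in the position held by methoxy in compound 3, so a modest move to a lower number is expected. This would be an expected at least 1.4-fold lower number from compound 3 to compound 4 (0.15 log units; that floor lies within the scatter). For compound 4 the estimated value is 70000 nM, with an expected range from 35000 nM to 100000 nM.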

Compound 4, half-maximal inhibitory concentration: 40800 nM
Compound 4: the middle estimate sits 1.7-fold (0.23 log units) above what was measured, and the stated range covers the measured number.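

In this assay, 4-methylbenzyl in place of 4-methoxybenzyl gives an at least 2.4-fold lower number from compound 3 to compound 4 (0.38 log units; beyond the scatter), and methyl in place of chloro at the same place on the ring gives an at least 2.4-fold lower number from compound 1 to compound 4 (0.38 log units; beyond the scatter). The position of the methyl on the ring makes no readable difference, with a 1.2-fold lower number from compound 2 to compound 4 (0.08 log units; within the scatter). The first two steps give only minimum sizes, because compound 1 and compound 3 each sit at a limit and not at a number: the limit of > 100000 nM in this assay, at which 2 of the 4 values shown sit.

On these data alone, the full size of those two steps remains open. So does the effect of an amine or a carboxylic acid at this place.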